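Amino in place of methoxymethoxy: expected cytotoxicity of compound 4

The source may hold more compounds than are shown below. What is called first, only, known or untested is meant among the compounds shown, and "the series" means these compounds.

compound 1 `COCOc1cccc(C(=O)/C=C/c2ccc3c(c2)B(O)OC3)c1` — > 10 ug/mL
compound 2 `COc1cccc(C(=O)CCc2ccc3c(c2)B(O)OC3)c1` — > 10 ug/mL
compound 3 `O=C(/C=C/c1ccc2c(c1)B(O)OC2)c1ccc([N+](=O)[O-])cc1` — > 10 ug/mL

In an ADME assay on L929 cells (Mus musculus) for cytotoxicity, read by resazurin assay, with a stated time of 72 h (a higher number here means a weaker inhibitor, a lower number a stronger inhibitor), compound 1 gives only a limit of the assay, > 10 ug/mL. Compound 2 likewise gives a limit, > 10 ug/mL. Compound 3 also gives a limit, > 10 ug/mL. Every value shown therefore sits at the limit of > 10 ug/mL in this assay, at which 3 of the 3 values shown sit, and no number places compound 1 above or below the other two; it stands with them at the edge of what this assay reports.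

Compound 4 `Nc1cccc(C(=O)/C=C/c2ccc3c(c2)B(O)OC3)c1` differs from compound 1 in one place: amino in place of methoxymethoxy on an aromatic carbon. For the measured compounds named here, no pair of measured compounds differing in one place is available, so no measured step guides this change. With all three measured compounds at the limit, compound 4 is expected to move no further than the usual scatter, and the step that the limit leaves unreadable from compound 1 to compound 4 is estimated accordingly. Compound 4 is thus expected to give about 15 ug/mL in this assay, within a range of 5 ug/mL to 50 ug/mL, most likely again reported only as a limit.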

Compound 4, half-maximal inhibitory concentration: 10 ug/mL
Compound 4: the middle estimate sits 1.5-fold (0.18 log units) above what was measured, within the range that was stated.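

For the compounds shown here, with amino in place of methoxymethoxy, compound 4 gives 10 ug/mL in this assay, the first plain number at this position. Compound 1 gives > 10 ug/mL, which is a limit of the assay. The change is recorded as a number no higher from compound 1 to compound 4 (the limit leaves the size open), and its size cannot be read because the comparison rests on a limit, which is also where most of the values stand: the limit of > 10 ug/mL in this assay, at which 3 of the 4 values shown sit.

The compounds shown leave open whether a different group on this aromatic carbon, such as a hydroxyl, a carboxylic acid or a dimethylamino group, would also give a plain number in this assay. Going by these compounds alone, they also leave open how far any such group would lie from compound 4, whose value is the only number available for comparison.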